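The source may report more compounds than this note shows. Statements on the series, on what has been measured and on what is new or still open speak of the compounds shown alone.

Of the compounds shown here, three that share one core have been measured in a functional assay on MDA-MB-435 cells (Homo sapiens) for antiproliferative activity, read by sulforhodamine B assay, with a stated time of 72 h; on this read-out lower numbers stand for stronger inhibition and higher numbers for weaker inhibition. Compound 1 `O=C1CS/C(=N/Nc2nncc3ccccc23)N1c1ccccc1` gives 44 nM in this assay, compound 2 `NC(=S)NNc1nncc2ccccc12` gives 52 nM, and compound 3 `O=S(=O)(Nc1ccccn1)c1ccc(Nc2nncc3ccccc23)cc1` gives 36 nM. Compound 3 has the lowest of the three numbers, but its gap to compound 1 and its gap to compound 2 both lie within the usual scatter of repeated measurements, so on these numbers the three compounds cannot be told apart.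

Compound 4 `O=S(=O)(Nc1ncccn1)c1ccc(Nc2nncc3ccccc23)cc1` has not yet been measured. It differs from compound 3 in one place: pyrimidin-2-yl in place of pyridin-2-yl on a sulfonamide nitrogen. Among the measured compounds shown here, no step between two measured compounds is available that would show what this kind of change does to the read-out, so the expectation for compound 4 rests on compound 3 alone. Compound 3 gives 36 nM in this assay, and the change swaps one six-membered aromatic ring for another of the same size with one more hetero atom. The step is expected to stay within the scatter: a 1.1-fold higher number from compound 3 to compound 4 (0.05 log units; within the scatter). Compound 4 is therefore estimated at 40 nM in this assay, with a range from 15 nM to 110 nM within which most repeat measurements should fall.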

Compound 4, half-maximal inhibitory concentration: 45 nM
Compound 4: the middle estimate sits 1.1-fold (0.05 log units) below what was measured; low and high end bracket the measured number.
By their numbers in this assay, from the lowest: compounds 3, 1, 4 and 2 (each within the scatter of the next).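

On a sulfonamide nitrogen, pyrimidin-2-yl can stand in place of pyridin-2-yl with no difference that can be told from repeat scatter: in this assay, the swap gives a 1.3-fold higher number from compound 3 to compound 4 (0.10 log units; within the scatter). Among the compounds shown here, this is the first step that joins two compounds differing in one place, and it shows that one more hetero atom in this six-membered aromatic ring, along with the extra hydrogen-bond acceptor counted for it, leaves compound 3 and compound 4 indistinguishable on this read-out. No measurement is available that explains this outcome.

From the compounds shown here alone, both groups seen at this position are six-membered aromatic rings, so it remains open whether the same holds for a different kind of group on the sulfonamide nitrogen, such as a methyl, a five-membered thiazol-2-yl ring or a plain hydrogen. Compound 1 and compound 2 differ from this pair in more than one place, so they cannot show what the sulfonamide-bearing part adds to the shared core.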